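The compounds below may be only part of what the source reports. "The series", "measured", "known", "first", "only" and "open" are said of these compounds alone.

Measured in a physicochemical assay for lipophilicity, using the shake flask method; a higher number here means a more lipophilic compound, a lower number a more polar compound:
compound 1 `O=C(Nc1ccc(C(F)(F)F)cc1)NC1CCN(C(=O)CCC(F)(F)F)CC1`: 3.66
compound 2 `CCC(C)C(=O)N1CCC(NC(=O)Nc2ccc(C(C)C)cc2)CC1`: 4.21

Compound 2, at 4.21, stands highest of the two, and the gap down to compound 1, at 3.66, lies beyond the scatter. Compound 3 `CCC(C)C(=O)N1CCC(NC(=O)Nc2ccc(C(F)(C(F)(F)F)C(F)(F)F)cc2)CC1` has not yet been measured. It carries 1,2,2,2-tetrafluoro-1-(trifluoromethyl)ethyl in place of isopropyl on an aromatic carbon. Within the data shown here, no measured pair differs in one place only, so the expectation rests on the structural change alone. In this assay, a rise beyond the scatter is expected, with an estimated a number 0.79 log units higher from compound 2 to compound 3 (beyond the scatter). Compound 3 is estimated at 5, with an expected range of 4.5 to 5.6.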

Compound 3, partition coefficient: 4.96
Compound 3: middle estimate off by 0.04 log units, on the high side, and the stated range covers the measured number.
By their numbers in this assay, from the lowest: compound 1; then compound 2; then compound 3.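

Among these compounds, compound 3 provides the first comparison at this position that differs in one place only: on this aromatic carbon, 1,2,2,2-tetrafluoro-1-(trifluoromethyl)ethyl in place of isopropyl gives in this assay a number 0.75 log units higher from compound 2 to compound 3 (beyond the scatter) and so raises the number on the shared core. Nothing measured here bears on the cause of this rise.

From the compounds shown here alone, it remains open what a nitrile, a carboxylic acid or an amine would give at this position, and whether the same exchange would give a similar step on the core of compound 1.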